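Swapping 3-methylphenyl for 4-isopropylphenyl: what to expect

The compounds below may be only part of what the source reports. "The series", "measured", "known", "first", "only" and "open" are said of these compounds alone.

Values from an ADME assay on BJ cells (Homo sapiens) for cytotoxicity, with a stated time of 72 h (a higher number here means that more compound is needed for the effect, a lower number that less compound is needed), follow
compound 1 `COc1ccc(-c2nc3c(c(C)nn3-c3ccccc3)c(-c3ccccc3O)c2C#N)cc1` gives > 23000 nM as a limit
compound 2 `Cc1cccc(-c2nc3c(c(C)nn3-c3ccccc3)c(-c3ccccc3O)c2C#N)c1` gives > 20000 nM as a limit

Among the compounds with values here, compound 2 therefore has no exact value, and the only other measured compound also has just a limit. Compound 3 `Cc1nn(-c2ccccc2)c2nc(-c3ccc(C(C)C)cc3)c(C#N)c(-c3ccccc3O)c12` carries 4-isopropylphenyl in place of 3-methylphenyl on an aromatic carbon on an aromatic carbon ortho to a cyano group, while the rest of the molecule stays the same.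

Within the data shown here, only one measured step changes a group on this carbon, a step that the two limits leave unreadable from compound 1 to compound 2, and two limits give it no readable size. It therefore offers no size or direction to carry over. The expected step is a number no higher from compound 2 to compound 3 (the limit leaves the size open) in this assay, with no change beyond the scatter foreseen. Compound 3 is estimated at 20000 nM, within a range from 8000 nM to 40000 nM, and the result may well be only a limit again.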

Compound 3, half-maximal effective concentration: 22600 nM
For compound 3 the middle estimate is 1.1-fold (0.05 log units) below the measured one; the measured number falls inside the stated range.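

In this assay compound 3 gives 22600 nM, so with 4-isopropylphenyl on this carbon, ortho to a cyano group, the series has its first exact number rather than a limit. Within the data shown here, the only readable comparison is an at least 1.0-fold lower number from compound 1 to compound 3 (0.00 log units; that floor lies within the scatter), and since that floor lies within the scatter, it shows no real change from swapping methoxy for isopropyl. The steps involving compound 2 cannot be read, as compound 2 holds only a limit: the limit of > 20000 nM in this assay, at which 1 of the 3 values shown sits.

From the compounds shown here alone, with so few values, it remains open whether any group at this position can shift the number beyond the scatter. An amine or a carboxylic acid on the phenyl ring, or a longer chain in place of isopropyl, might show whether this carbon matters for the read-out at all.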